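The source may hold more compounds than are shown below. What is called first, only, known or untested is meant among the compounds shown, and "the series" means these compounds.

Measured compounds in a binding assay on brain for binding affinity to Neuronal acetylcholine receptor; alpha4/beta2 (Rattus norvegicus), read by radioligand binding; on this read-out lower numbers stand for stronger inhibition and higher numbers for weaker inhibition:
- compound 1 `CCc1ccc(OC[C@@H]2CCN2)cn1` — compound 1 gives 19 nM
- compound 2 `c1ccc(-c2ccc(OC[C@@H]3CCN3)cn2)cc1` — compound 2 gives 2.3 nM
- compound 3 `N#Cc1cncc(OC[C@@H]2CCN2)c1` — compound 3 gives 0.025 nM

Compound 3 stands lowest of the three numbers in this assay, beyond the scatter against both compound 2 and compound 1, so it is the most potent compound in the set.

Compound 4 `CCCc1cncc(OC[C@@H]2CCN2)c1` has not been measured. It differs from compound 3 in one place: propyl in place of cyano on an aromatic carbon. The cyano, which carries the single hydrogen-bond acceptor of the substituent, is thereby lost.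

Going by the values given here, the only measured step, an 8.3-fold lower number from compound 1 to compound 2 (0.92 log units; beyond the scatter), concerns a phenyl replacing ethyl on an aromatic carbon; it does not touch a cyano and sits on a different aromatic carbon, so it bears on the present change only loosely. Compound 1 and compound 2 show what alkyl and aryl groups on the core give in this assay, and both lie well above compound 3. On that basis a clear rise in the number from compound 3 to compound 4 is expected, an 80-fold higher number from compound 3 to compound 4 (1.90 log units; beyond the scatter), though not all the way back to compound 1. Compound 4 is expected to give 2 nM in this assay, within the range 0.3 nM to 15 nM.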

Compound 4, inhibition constant: 0.039 nM
Compound 4: the middle estimate sits 51-fold (1.71 log units) above what was measured; the whole stated range lies above it.
By their numbers in this assay, from the lowest: compounds 3 and 4 (each within the scatter of the next); then compound 2; then compound 1.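

In this assay, propyl in place of cyano on an aromatic carbon, two atoms from the ring nitrogen, gives a 1.6-fold higher number from compound 3 to compound 4 (0.19 log units; within the scatter), so this change cannot be told apart from no change at this position. The hydrogen-bond acceptor of the cyano leaves and the propyl brings none, yet compound 4 gives 0.039 nM, so within this pair an acceptor in the substituent is not needed for a value of this size, and neither is a triple bond. No measured evidence at hand bears on why these two groups match here.

As far as these compounds go, one pair says little about how wide this tolerance is: what a longer chain such as hexyl, an amine or a carboxylic acid would give on this aromatic carbon remains open. Going by these compounds alone, also open is whether phenyl, seen only on a different aromatic carbon in compound 2, would match cyano and propyl at this position, and whether the match holds in any read-out other than this binding assay.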